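Lengthening the Amide Chain of Compound 1

The source may hold more compounds than are shown below. What is called first, only, known or untested is meant among the compounds shown, and "the series" means these compounds.

Compound 1 `CCC1C(=O)N(C)c2cnc(-n3ccc4cc(C(=O)NC)ccc43)nc2N1c1ccn(C)n1` gives 13300 nM
Compound 2 `CC[C@@H]1C(=O)N(C)c2cnc(-n3ccc4cc(C(=O)NCC(C)C)ccc43)nc2N1C1CCCC1` gives 638 nM

In a functional assay on K562 cells (Homo sapiens) for antiproliferative activity, read by CCK-8 assay, with a stated time of 72 h (a higher number here means a weaker inhibitor of growth, a lower number a stronger inhibitor of growth), compound 1 gives 13300 nM, the higher of the two numbers, so it is the weaker growth inhibitor of the pair, while compound 2 gives 638 nM. Compound 3 `CCC1C(=O)N(C)c2cnc(-n3ccc4cc(C(=O)NCC(C)C)ccc43)nc2N1c1ccn(C)n1` has not yet been measured. It differs from compound 1 by isopropyl in place of hydrogen on a saturated chain carbon bound to an amide-type nitrogen, with isopropyl in place of hydrogen on a saturated chain carbon bound to an amide-type nitrogen. This turns methylcarbamoyl into isobutylcarbamoyl. Within the data shown here, compound 2 at 638 nM also carries isobutylcarbamoyl, but it differs from compound 3 elsewhere too, so no measured pair isolates this change. A moderate fall beyond the scatter in this assay is therefore expected, smaller than the whole gap between the two measured values. The estimated change is a 3.8-fold lower number from compound 1 to compound 3 (0.58 log units; beyond the scatter). For compound 3 the expected value is 3500 nM, within an estimated range of 1000 nM to 11000 nM.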

Compound 3, concentration for 50% growth inhibition: 5600 nM
Compound 3: the middle estimate sits 1.6-fold (0.20 log units) below what was measured; low and high end bracket the measured number.
By their numbers in this assay, from the lowest: compound 2; then compound 3; then compound 1.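

In this assay, among these compounds, the change from methylcarbamoyl to isobutylcarbamoyl on the core of compound 1 gives a 2.4-fold lower number from compound 1 to compound 3 (0.38 log units; beyond the scatter) as a modest step, the first reading of this change on its own. Among the compounds shown here, it shows that the number responds to the group on this amide-type nitrogen, although compound 3 differs from compound 2 in more than one place, so no step between those two can be read. No measurement shown bears on the reason for this step.

What the compounds shown leave open is how the number moves along the series from methyl to isobutyl and beyond, with an ethyl group, a longer straight chain, or a chain ending in an amine or a carboxylic acid. As far as these compounds go, it also remains open whether the same change gives a similar step with the other groups of compound 2 in place.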